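A few compounds are considered here, and "the series" means these few. Any claim that something is new, unique, unknown or untested is made for them only; others in the source may bear on it.

Measured in a functional assay on BXPC-3 cells (Homo sapiens) for antiproliferative activity, read by MTT assay, with a stated time of 24 h; a lower number here means a stronger inhibitor, a higher number a weaker inhibitor:
- Compound 1 `CCn1c(C(=O)N[C@@H](C)CO)ccc1C(CC)(CC)c1ccc(OCS(=O)(=O)c2ccccc2)c(C)c1` gives 15300 nM
- Compound 2 `CCn1c(C(=O)N[C@@H](CO)CCO)ccc1C(CC)(CC)c1ccc(OCS(=O)(=O)c2ccccc2)c(C)c1` gives > 50000 nM (a limit, not a number)

Compound 2 stands at the limit of > 50000 nM in this assay, at which 1 of the 2 values shown sits. Its true value is therefore not known.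

Compound 3 `CCn1c(C(=O)N[C@@H](CO)CCCO)ccc1C(CC)(CC)c1ccc(OCS(=O)(=O)c2ccccc2)c(C)c1` differs from compound 2 by hydroxymethyl in place of hydroxy on a saturated chain carbon, three bonds along the chain from an amide-type nitrogen. This is hydroxymethyl in place of hydroxy on a saturated chain carbon, three bonds along the chain from an amide-type nitrogen. Cut one bond further out, the same difference reads 2-hydroxyethyl to 3-hydroxypropyl.

For the measured compounds named here, one measured step bears on this change: an at least 3.2-fold higher number from compound 1 to compound 2 (0.51 log units; beyond the scatter). That step placed 3-hydroxy-1-(hydroxymethyl)propyl in place of 1-(hydroxymethyl)ethyl on an amide-type nitrogen. It ended at a limit, so its full size is open, and a single step sets no trend. The weakening seen there is not expected to reverse with the further extension, and no change beyond the scatter is expected in this assay. The expected step is a number no higher from compound 2 to compound 3 (the limit leaves the size open). The estimate for compound 3 is 50000 nM, with an expected range from 20000 nM to 100000 nM.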

Compound 3, half-maximal inhibitory concentration: 16400 nM
Compound 3: middle estimate off by 3.0-fold (0.48 log units), on the high side, and the stated range ends above it.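

In this assay, the difference at this position, read as 3-hydroxypropyl in place of 2-hydroxyethyl, gives an at least 3.0-fold lower number from compound 2 to compound 3 (0.48 log units; beyond the scatter), so the weakening seen on going to the 2-hydroxyethyl side chain does not continue as the chain grows by one carbon. Against the smaller 1-(hydroxymethyl)ethyl group on the amide-type nitrogen, the larger group of compound 3 gives a 1.1-fold higher number from compound 1 to compound 3 (0.03 log units; within the scatter), which means that added size on this nitrogen does not by itself track with a higher number, and of the three compounds only compound 2 stands apart. The value of compound 2 is a limit and not a number, so the step out of it is bounded on one side only: the limit of > 50000 nM in this assay, at which 1 of the 3 values shown sits.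

Three compounds do not show whether the response at this position follows the length of the chain or is peculiar to the 2-hydroxyethyl side chain, and a longer chain such as 4-hydroxybutyl would bear on that. Nor do they show whether the terminal hydroxy itself matters, a question that 3-methoxypropyl or 3-aminopropyl in place of 3-hydroxypropyl would address.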